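Methoxy in Place of Carboxy on a Hydroxamate Inhibitor

A few compounds are considered here, and "the series" means these few. Any claim that something is new, unique, unknown or untested is made for them only; others in the source may bear on it.

Measured compounds:
compound 1, `CCCCC[C@@H](C(=O)NCNC(=O)c1cc2cccc(OC)c2o1)[C@H](CC)N(O)C=O`: > 10000 nM
compound 2, `CCCCC[C@H](CN(O)C=O)C(=O)NCNC(=O)c1ccc(-c2cccc(C(=O)O)c2)o1`: 8 nM

Within the data shown here, in an assay on CHO cells for inhibition of bone morphogenetic protein 1 (Homo sapiens), with stated times of 10 min and 60 min (a higher number here means a weaker inhibitor, a lower number a stronger inhibitor), compound 2 gives 8 nM, the only number obtained so far. For compound 1 the result is a limit of the assay, > 10000 nM. Compound 3, `CCCCC[C@H](CN(O)C=O)C(=O)NCNC(=O)c1ccc(-c2cccc(OC)c2)o1`, differs from compound 2 by methoxy in place of carboxy on an aromatic carbon. Among the measured compounds shown here, no measured pair differing in one place exists here, so the expectation rests on compound 2 alone. A loss of potency beyond the scatter is expected, with an estimated step of a 7.5-fold higher number from compound 2 to compound 3 (0.88 log units; beyond the scatter). Compound 3 is expected to give about 60 nM, within a range from 10 nM to 400 nM.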

Compound 3, half-maximal inhibitory concentration: 20 nM
Estimate against measurement, compound 3: 3.0-fold (0.48 log units) above, and the stated range covers the measured number.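

In this assay, methoxy in place of carboxy on this aromatic carbon gives a 2.5-fold higher number from compound 2 to compound 3 (0.40 log units; beyond the scatter), so this position tolerates the loss of the carboxy group at only a modest cost. With the 3-methoxyphenyl group, compound 3 still gives 20 nM. Nothing measured here accounts for the size of this step.

As far as these compounds go, whether an amine, a hydroxyl or a plain hydrogen on this carbon would keep the number as low remains open. So does whether methoxy would behave the same way on another carbon of this ring.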